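A Methoxyphenyl Urea in a Weakly Cytotoxic Series

This account rests on a few compounds, and the source may have more. Where it says the series, first, only, none or still open, it means among the compounds named here.

Compound 1 `Cc1ccc(NC(=O)N[C@H]2CC[C@H](Oc3ccc(F)cc3)CC2)cc1` is one of three ureas on a shared core tested in a functional assay on CRL2813 cells (Homo sapiens) for cytotoxicity, read by sulforhodamine B assay, with a stated time of 5 days; a lower number here means a stronger inhibitor, a higher number a weaker inhibitor. For compound 1 this assay returns a limit of the assay rather than a number: compound 1 gives > 20000 nM. Where compound 1 stands is therefore known only as a bound, and one of the three values shown sits at that bound (the limit of > 20000 nM in this assay, at which 1 of the 3 values shown sits). Compound 2 `O=C(Nc1ccc(F)cc1)N[C@H]1CC[C@H](Oc2ccc(F)cc2)CC1` gives 20000 nM in this assay, and the step of a number no higher from compound 1 to compound 2 (the limit leaves the size open) has no readable size. Compound 3 `O=C(Nc1cccc(C(F)(F)F)c1)N[C@H]1CC[C@@H](Oc2ccc(F)cc2)CC1` carries a trifluoromethyl group and differs from compound 1 in several places. In this assay compound 3 gives 2600 nM.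

The unmeasured compound 4 `COc1cccc(NC(=O)N[C@H]2CC[C@H](Oc3ccc(F)cc3)CC2)c1` differs from compound 1 by 3-methoxyphenyl in place of 4-methylphenyl on an amide-type nitrogen. No measured step touches this change; the only single step shown, from compound 1 to compound 2, leaves its size open. No direction beyond the scatter can therefore be expected for compound 4 in this assay. Compound 4 is estimated at 15000 nM in this assay, within 5000 nM to 40000 nM. That estimate means an expected step of an at least 1.3-fold lower number from compound 1 to compound 4 (0.12 log units; that floor lies within the scatter), and compound 4 may itself return only a limit.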

Compound 4, half-maximal inhibitory concentration: 14000 nM
Estimate against measurement, compound 4: 1.1-fold (0.03 log units) above; low and high end bracket the measured number.
By their numbers in this assay, from the lowest: compound 3; then compounds 4 and 2 (each within the scatter of the next).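

Placing 3-methoxyphenyl on the amide-type nitrogen gives the first step at this position with a readable floor in this assay: an at least 1.4-fold lower number from compound 1 to compound 4 (0.15 log units; that floor lies within the scatter). That floor does not establish a change beyond the scatter. Among the compounds shown here, the comparison with the 4-fluorophenyl urea is the first at this position with a full size, a 1.4-fold lower number from compound 2 to compound 4 (0.15 log units; within the scatter), so in this assay these two aryl groups are not told apart, even though the 3-methoxyphenyl group brings an oxygen and a hydrogen-bond acceptor. The full size of the step from compound 1 remains open because compound 1 has a limit of the assay and not a number: the limit of > 20000 nM in this assay, at which 1 of the 4 values shown sits.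

On these data alone, what an amine or a carboxylic acid in place of the methoxy group would give on the shared core remains open. Also open, as far as these compounds go, is how much of the value of compound 3 belongs to its trifluoromethyl group, as compound 3 differs from the other compounds in more than one place.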